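Fluorophenyl amides: the step from compound 3 to compound 4

This account rests on a few compounds, and the source may have more. Where it says the series, first, only, none or still open, it means among the compounds named here.

In an ADME assay on LLC-MK2 cells (Macaca mulatta) for cytotoxicity, read by spectrophotometry and crystal violet staining, with a stated time of 4 days (on this read-out higher numbers stand for lower toxicity in this test and lower numbers for higher toxicity in this test), compound 1 (`CC(C)n1ncc2c(C(=O)Nc3ccncc3)cc(-c3cccs3)nc21`), which carries pyridin-4-yl on the amide-type nitrogen, gives 6300 nM. Compound 2 (`CC(C)n1ncc2c(C(=O)Nc3cccc(F)c3)cc(-c3cccs3)nc21`) gives only a limit of the assay, > 200000 nM. Compound 3 (`CC(C)n1ncc2c(C(=O)Nc3c(F)cc(F)cc3F)cc(-c3cccs3)nc21`) likewise gives only a limit, > 200000 nM, so it stands without a number of its own. The three values include (the limit of > 200000 nM in this assay, at which 2 of the 3 values shown sit).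

Compound 4 (`CC(C)n1ncc2c(C(=O)Nc3ccccc3F)cc(-c3cccs3)nc21`) differs from compound 3 by one change: 2-fluorophenyl in place of 2,4,6-trifluorophenyl on an amide-type nitrogen. For the measured compounds named here, two measured steps bear on it, both large: an at least 31-fold higher number from compound 1 to compound 2 (1.50 log units; beyond the scatter) and an at least 31-fold higher number from compound 1 to compound 3 (1.50 log units; beyond the scatter). Each replaces pyridin-4-yl with a fluorine-bearing phenyl, as compound 4 also has. The remaining comparison is a step that the two limits leave unreadable from compound 2 to compound 3, so the effect of the fluorine count cannot be read. In this assay, no step beyond the scatter is expected, and a further limit is quite likely. The estimated outcome is an at least 1.1-fold lower number from compound 3 to compound 4 (0.04 log units; that floor lies within the scatter). For compound 4 the expected value is 180000 nM, with an estimated range of 50000 nM to 400000 nM.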

Compound 4, half-maximal cytotoxic concentration: 50000 nM
Compound 4: middle estimate off by 3.6-fold (0.56 log units), on the high side, within the range that was stated.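

In this assay, a fluorine-bearing phenyl on the amide-type nitrogen does not by itself reach the limit, as 2-fluorophenyl gives an at least 4.0-fold lower number from compound 3 to compound 4 (0.60 log units; beyond the scatter) and an at least 4.0-fold lower number from compound 2 to compound 4 (0.60 log units; beyond the scatter). The same group still keeps a clear distance from pyridin-4-yl, with a 7.9-fold higher number from compound 1 to compound 4 (0.90 log units; beyond the scatter), so this position separates the three fluorophenyl amides as well as setting them apart from the pyridine. Both steps to compound 4 from the other fluorophenyl amides are floors and not sizes, because compound 2 and compound 3 give only limits: the limit of > 200000 nM in this assay, at which 2 of the 4 values shown sit.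

The step between compound 2 and compound 3 cannot be read, so the roles of fluorine count and fluorine placement remain unseparated. Where plain phenyl, a chlorophenyl or an aminophenyl on the same nitrogen would fall also remains open.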